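Pyrrole amide to propargyl ester in a secosteroid mimic series

The source may report more compounds than this note shows. Statements on the series, on what has been measured and on what is new or still open speak of the compounds shown alone.

Measured so far:
compound 1 `CCn1c(C(=O)NCCN)ccc1C(CC)(CC)c1ccc(OCCC(O)(CC)CC)c(C)c1` — 156 nM
compound 2 `CCn1c(C(=O)N(CCC#N)CCC#N)ccc1C(CC)(CC)c1ccc(OCCC(O)(CC)CC)c(C)c1` — > 10000 nM

Of the compounds shown here, two have been measured in an assay on cells for agonist activity at vitamin D3 receptor (Homo sapiens), with a stated time of 96 h; a lower number here means that less compound is needed, a higher number that more compound is needed for the effect. Compound 1 gives 156 nM. Compound 2 reaches only the limit of this assay, > 10000 nM, so no number is known for it, and it stands at the weak end of what has been seen (the limit of > 10000 nM in this assay, at which 1 of the 2 values shown sits). Among the measured compounds shown here, the one measured step, an at least 64-fold higher number from compound 1 to compound 2 (1.80 log units; beyond the scatter), shows that the group on the carbonyl carbon governs a large part of the activity.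

Compound 3 `C#CC(C)OC(=O)c1ccc(C(CC)(CC)c2ccc(OCCC(O)(CC)CC)c(C)c2)n1CC` is not yet measured. It differs from compound 2 by a group of 5 heavy atoms (4 carbon, 1 oxygen; no ring) in place of a group of 9 heavy atoms (6 carbon, 3 nitrogen; no ring), on a carbonyl carbon. For the measured compounds named here, the only step that bears on this carbonyl position is the large one from compound 1 to compound 2, and it runs in the other direction, from a smaller to a larger group. The expected step here is an at least 6.6-fold lower number from compound 2 to compound 3 (0.82 log units; beyond the scatter). Compound 2 stands at a limit, and the size of this expected change remains uncertain. For compound 3 the expected value in this assay is 1500 nM, in the range 150 nM to 10000 nM.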

Compound 3, half-maximal effective concentration: 2650 nM
Compound 3: the middle estimate sits 1.8-fold (0.25 log units) below what was measured; the range from low to high includes it.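

In this assay the (1-methylprop-2-yn-1-yl)oxy group on the carbonyl carbon gives a measurable value, with an at least 3.7-fold lower number from compound 2 to compound 3 (0.57 log units; beyond the scatter) for this change, so a measurable value at this position does not depend on an amide nitrogen. That step is only a lower bound because compound 2 stands at a limit of the assay: the limit of > 10000 nM in this assay, at which 1 of the 3 values shown sits. The same group still falls short of the (2-aminoethyl)amino group, with a 17-fold higher number from compound 1 to compound 3 (1.23 log units; beyond the scatter) as the gap, so the (2-aminoethyl)amino group gives the lowest number of the three groups on this carbonyl carbon.

Open, on these data alone, is how much of the gap belongs to the terminal amine and how much to the amide hydrogen. Also open, as far as these compounds go, is whether the alkyne matters, which a simple ethyl ester or a carboxylic acid on the same carbonyl carbon would test.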